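A few compounds are considered here, and "the series" means these few. Any claim that something is new, unique, unknown or untested is made for them only; others in the source may bear on it.

The series shares one core, seen in compound 1 `O=C(NCc1cccc(Cn2cnc3ccccc32)c1)c1cc2ccccc2o1`, compound 2 `O=C(NCc1cccc(Cn2cnc3ccccc32)c1)c1cc2ccccc2[nH]1` and compound 3 `O=C(NCc1cccc(Cn2cnc3ccccc32)c1)c1ccc(Br)cc1`; the three differ only in the group attached to the carbonyl carbon. In an assay for inhibition of Indoleamine 2,3-dioxygenase 1 (Homo sapiens), read by HPLC, with a stated time of 48 h (on this read-out lower numbers stand for stronger inhibition and higher numbers for weaker inhibition), compound 1 gives 413 nM, compound 2 gives 72 nM, and compound 3 gives 134 nM. Compound 3 thus stands second highest of the three numbers: its nearest neighbour is compound 2, a gap within the scatter, while compound 1 lies further off, with a 3.1-fold lower number from compound 1 to compound 3 (0.49 log units; beyond the scatter). Compound 4 `N#Cc1ccc(C(=O)NCc2cccc(Cn3cnc4ccccc43)c2)cc1` keeps the whole of compound 3 except for one change: cyano in place of bromo on an aromatic carbon. Going by the values given here, no measured step alters a substituent on that six-membered ring; the steps known, a 5.7-fold lower number from compound 1 to compound 2 (0.76 log units; beyond the scatter) and a 1.9-fold higher number from compound 2 to compound 3 (0.27 log units; within the scatter), all exchange the whole ring system on the carbonyl carbon, and even the larger of them is modest. A single substituent swap on a ring that otherwise stays in place is therefore expected to move this assay by no more than the scatter, in no clear direction. The step from compound 3 to compound 4 is estimated at a 1.1-fold higher number from compound 3 to compound 4 (0.05 log units; within the scatter). Compound 4 is expected to give about 150 nM in this assay, with a range from 50 nM to 450 nM.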

Compound 4, half-maximal inhibitory concentration: 90 nM
Compound 4: the middle estimate sits 1.7-fold (0.22 log units) above what was measured; the measured number falls inside the stated range.
By their numbers in this assay, from the lowest: compounds 2, 4 and 3 (each within the scatter of the next); then compound 1.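

In this assay, cyano and bromo on the aromatic carbon para to a large group cannot be told apart, with a 1.5-fold lower number from compound 3 to compound 4 (0.17 log units; within the scatter), so this first substituent swap on the ring that stays in place leaves the number within the scatter. The 4-cyanophenyl group also cannot be told apart from the 1H-indol-2-yl group on the carbonyl carbon, with a 1.3-fold higher number from compound 2 to compound 4 (0.10 log units; within the scatter), while it keeps a gap beyond the scatter from the 1-benzofuran-2-yl group, with a 4.6-fold lower number from compound 1 to compound 4 (0.66 log units; beyond the scatter), so compound 3 and compound 4 both stand apart from compound 1 and neither stands apart from compound 2. Nothing among the data shown explains these results.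

The compounds shown leave open whether this position would stay as flat with an amine, a carboxylic acid or a longer chain in place of cyano or bromo, since two substituents cannot show how far that flatness extends. They also leave open how the unsubstituted phenyl ring would compare, and whether the same swap would read alike with the substituent elsewhere on the ring.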